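The compounds below may be only part of what the source reports. "The series", "measured", "known", "first", "only" and "open" are said of these compounds alone.

Compound 3 `COc1ccc([C@@H]2C/C(=N/OCc3cn(-c4ccc(O)cc4)nn3)c3cc(CC=C(C)C)c(OC)cc3O2)cc1` gives 52% in a functional assay on A549 cells (Homo sapiens) for inhibition, read by sulforhodamine B assay, with a stated time of 48 h, tested at 50 uM (on this read-out lower numbers stand for less inhibition of growth and higher numbers for more inhibition of growth at the one concentration tested), the lowest of the three numbers in hand; compound 2 `C#CCO/N=C1/C[C@@H](c2ccc(OC)cc2)Oc2cc(OC)c(CC=C(C)C)cc21` gives 64% and compound 1 `COc1ccc([C@@H]2C/C(=N/OCc3cn(-c4ccccc4CO)nn3)c3cc(CC=C(C)C)c(OC)cc3O2)cc1` gives 100%. Compound 4 `COc1ccc([C@@H]2C/C(=N/OCc3cn(-c4ccc(C(N)=O)cc4)nn3)c3cc(CC=C(C)C)c(OC)cc3O2)cc1` differs from compound 3 by carbamoyl in place of hydroxy on an aromatic carbon. For the measured compounds named here, no measured step swaps this same group, but a number 48 percentage points lower from compound 1 to compound 3 (beyond the scatter) shows that the group carried on the aromatic nitrogen can move the read-out greatly, while a number 12 percentage points lower from compound 2 to compound 3 (beyond the scatter) was modest. A shift in either direction is therefore possible, and compound 4 is expected to show a number 10 percentage points higher from compound 3 to compound 4 (within the scatter), with considerable uncertainty. Compound 4 is estimated at 62%, between 35% and 90%.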

Compound 4, percent growth inhibition at one concentration: 100%
Compound 4: middle estimate off by 38 percentage points, on the low side, and the stated range ends below it.
By their numbers in this assay, from the lowest: compound 3; then compound 2; then compounds 1 and 4 (each within the scatter of the next).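

In this assay, carbamoyl in place of hydroxy on this aromatic carbon gives a number 48 percentage points higher from compound 3 to compound 4 (beyond the scatter), so a swap of this one small group is enough for a large change. Replacing the whole aryl group gives no change at the digits printed from compound 1 to compound 4 (within the scatter), so 4-carbamoylphenyl and 2-(hydroxymethyl)phenyl on the aromatic nitrogen cannot be told apart here. Nothing available explains the size of the step from hydroxy to carbamoyl. Going by these compounds, it remains open whether a carboxylic acid or an amine on this carbon would read like carbamoyl or like hydroxy. A single tested concentration also leaves open whether compound 1 and compound 4 would separate at lower concentrations.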